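Notes on the step to compound 3

A few compounds are considered here, and "the series" means these few. Any claim that something is new, unique, unknown or untested is made for them only; others in the source may bear on it.

Measured in a physicochemical assay for lipophilicity, measured as octanol-water partition, at pH 7.4; on this read-out higher numbers stand for higher lipophilicity and lower numbers for lower lipophilicity:
- compound 1 `Cc1ccc2[nH]c(C(=O)N[C@H]3CCN(S(=O)(=O)N(C)C)C[C@@H]3C(=O)NCCN(C)C)cc2c1` gives 1.2
- compound 2 `Cc1csc(C(=O)N[C@H]2CN(S(=O)(=O)c3ccccc3)C[C@@H]2C(=O)N[C@H]2CCCNC2)n1` gives 0.1

Compound 2 gives 0.1, the lower of the two numbers in this assay. Compound 1 gives 1.2, and this gap lies beyond the usual scatter. The two compounds differ in more than one place, so the gap cannot be tied to any single change.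

Compound 3 `O=C(N[C@H]1CN(S(=O)(=O)c2ccccc2)C[C@@H]1C(=O)N[C@H]1CCCNC1)c1nnc(-c2ccc(F)cc2)s1` differs from compound 2 in one place, on a carbonyl carbon: a group of 12 heavy atoms (8 carbon, 2 nitrogen, 1 fluorine, 1 sulfur; one five-membered aromatic ring with 3 hetero atoms, one six-membered aromatic ring of carbon only) in place of a group of 6 heavy atoms (4 carbon, 1 nitrogen, 1 sulfur; one five-membered aromatic ring with 2 hetero atoms), on a carbonyl carbon. The 4-methyl-1,3-thiazol-2-yl group leaves, and the entering group brings one six-membered aromatic ring of carbon only. Going by the values given here, no measured pair shows a step of this kind, so the expectation rests on the structural change alone. An upward move beyond the scatter is expected, with an estimated step of a number 1.30 log units higher from compound 2 to compound 3 (beyond the scatter). The estimated value for compound 3 is 1.4, with an expected range from 0.8 to 2.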

Compound 3, distribution coefficient: 1
Estimate against measurement, compound 3: 0.40 log units above, and the stated range covers the measured number.
By their numbers in this assay, from the lowest: compound 2; then compounds 3 and 1 (each within the scatter of the next).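

Going by these compounds alone, the first single-place step in this assay can be read here: a number 0.90 log units higher from compound 2 to compound 3 (beyond the scatter) follows when the 4-methyl-1,3-thiazol-2-yl group on the carbonyl carbon gives way to the larger group carrying a five-membered aromatic ring with 3 hetero atoms and a six-membered aromatic ring of carbon only. With the rest of compound 2 unchanged, the group at this one position is enough to move the read-out beyond the scatter, which the earlier gap between compounds differing in more than one place could not show. No measurement at hand accounts for the step. The compounds shown leave open which part of the entering group carries the step, the five-membered ring or the six-membered ring. From the compounds shown here alone, how a group bearing an amine or a carboxylic acid would read at this carbonyl carbon also stays open.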